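Amino Substitution on Chloromethylbenzyl Chloropurines

This account rests on a few compounds, and the source may have more. Where it says the series, first, only, none or still open, it means among the compounds named here.

Compound 1, `ClCc1ccc(Cn2cnc3c(Cl)ncnc32)cc1`: > 100000 nM
Compound 2, `Nc1nc(Cl)c2ncn(Cc3ccc(CCl)cc3)c2n1`: > 100000 nM
Compound 3, `ClCc1ccccc1Cn1cnc2c(Cl)ncnc21`: 5240 nM

In a functional assay on MOLT-4 cells (Homo sapiens) for cytotoxicity, read by sulforhodamine B assay, with a stated time of 48 h (on this read-out higher numbers stand for weaker inhibition of growth and lower numbers for stronger inhibition of growth), compound 1 reaches only the limit of the assay, > 100000 nM. Compound 2 likewise returns only the limit, > 100000 nM. Compound 3 gives a number, 5240 nM. The difference between the core of compound 1 and the core of compound 3 is not broken down here. Compound 2 arises from compound 1 by amino in place of hydrogen on an aromatic carbon, and that step, a step that the two limits leave unreadable from compound 1 to compound 2, cannot be sized because of the limit of > 100000 nM in this assay, at which 2 of the 3 values shown sit. Compound 4, `Nc1nc(Cl)c2ncn(Cc3ccccc3CCl)c2n1`, arises from compound 3 by the same change, (amino in place of hydrogen on an aromatic carbon). The measured example of this change gives no size, so the expectation for compound 4 rests mainly on compound 3 at 5240 nM. The expected step is a 1.5-fold higher number from compound 3 to compound 4 (0.18 log units; within the scatter) in this assay. Compound 4 is thus estimated at 8000 nM, likely between 2000 nM and 40000 nM.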

Compound 4, concentration for total growth inhibition: > 100000 nM
Compound 4 gave a limit, no number; the forecaster's own chance of this, stated with the estimate: 15%; at least 12-fold (1.09 log units) between middle value and limit.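

In this assay, on these data alone, amino in place of hydrogen on an aromatic carbon gives an at least 19-fold higher number from compound 3 to compound 4 (1.28 log units; beyond the scatter), a large weakening of growth inhibition whose full size stays unknown, as compound 4 returned only a limit of the assay and not a number. As far as these compounds go, whether the change does the same on the core of compound 1 remains unknown, and a single readable pair sets no rule for the series. The step from compound 1 to compound 2 cannot be read because both compounds stand at a limit: the limit of > 100000 nM in this assay, at which 3 of the 4 values shown sit.

The compounds shown leave open whether the weakening belongs to amino alone. A methylamino or methoxy group on the same aromatic carbon might behave quite differently.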